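Single-group swaps on the aryl ring of a shared core

The source may hold more compounds than are shown below. What is called first, only, known or untested is meant among the compounds shown, and "the series" means these compounds.

All three measured compounds were tested in a functional assay on the whole organism for inhibition, with Mus musculus as the target, with a stated time of 1 h, at a dose of 100 mg/kg by the intraperitoneal route; a lower number here means less inhibition, a higher number more inhibition at the dose given (going by the name of the read-out):
compound 1 `Cc1nc2ccccc2c(=O)n1NC(=O)Nc1ccc(Cl)cc1`: 48%
compound 2 `Cc1ccc(NC(=O)Nn2c(C)nc3ccccc3c2=O)cc1`: 52%
compound 3 `COc1ccc(NC(=O)Nn2c(C)nc3ccccc3c2=O)cc1`: 42%

Compound 2 returns the highest of the three numbers, but its separation from compound 1 and from compound 3 stays within the scatter, so no order among the three can be claimed. The three steps between them, a number 4 percentage points higher from compound 1 to compound 2 (within the scatter), a number 6 percentage points lower from compound 1 to compound 3 (within the scatter) and a number 10 percentage points lower from compound 2 to compound 3 (within the scatter), each exchange one group on the aromatic carbon para to the large group, and none moves the number beyond the scatter.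

Compound 4 `Cc1nc2ccccc2c(=O)n1NC(=O)Nc1ccc(F)cc1` is not yet measured. It differs from compound 2 by fluoro in place of methyl on an aromatic carbon. All three measured steps bear on this change, since each is the same kind of exchange at the same place, and all were within the scatter. By the same reasoning the step in this assay from compound 2 to compound 4 is expected to be small, a number 4 percentage points lower from compound 2 to compound 4 (within the scatter), with no direction beyond the scatter.

Compound 4 is therefore estimated to give 48% in this assay, with a range from 35% to 60%.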

Compound 4, a percentage reported as inhibition, in the whole organism at one dose (the size of the read-out at that dose, not a potency): 45%
The estimate for compound 4 lay 3 percentage points above the measured number; the measured number falls inside the stated range.
By their numbers in this assay, from the lowest: compounds 3, 4, 1 and 2 (each within the scatter of the next).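

In this assay, fluoro at this place on the aromatic ring, para to a large group, brings a fourth group into the comparison, and all of its steps stay within the scatter (a number 7 percentage points lower from compound 2 to compound 4 (within the scatter); a number 3 percentage points higher from compound 3 to compound 4 (within the scatter); a number 3 percentage points lower from compound 1 to compound 4 (within the scatter)). The 4-methylphenyl to 4-fluorophenyl change therefore gives no readable shift, and the exchange of chloro for fluoro, the first between two halogens here, does not separate compound 1 from compound 4 either. No measurement bears on why these exchanges leave the number within the scatter.

From the compounds shown here alone, compounds 1 to 4 cover only methyl, chloro, methoxy and fluoro at this place, so it remains open whether an amine, a carboxylic acid or a longer chain such as butoxy would give a step beyond the scatter. The read-out comes from a single dose and is not a potency, so the data also leave open whether differences among these four compounds would appear at other doses.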